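This account rests on a few compounds, and the source may have more. Where it says the series, first, only, none or still open, it means among the compounds named here.

Three compounds have been measured so far in a physicochemical assay for lipophilicity, using the shake flask method, measured as octanol-water partition (on this read-out lower numbers stand for lower lipophilicity and higher numbers for higher lipophilicity), and give these numbers:

- compound 1 `O=C(N/N=C/c1ccc(CO)cc1)c1ccncc1` gives 0.731
- compound 2 `CCCCCC(C)C(=O)NNC(=O)c1ccncc1` gives 2.09
- compound 3 `O=C(N/N=C/c1cccc(CO)c1)c1ccncc1` gives 0.902

Compound 1 (0.731) and compound 3 (0.902) lie within the usual scatter of repeated measurements, so these two numbers cannot be told apart. Compound 2 (2.09) stands clearly higher than compound 1, by more than that scatter.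

The next compound to be measured is compound 4 `O=Cc1ccc(/C=N/NC(=O)c2ccncc2)cc1`, which keeps the core of compound 1 and changes it in one place. It carries formyl in place of hydroxymethyl on an aromatic carbon, para to a large group (formyl in place of hydroxymethyl on an aromatic carbon). Among the compounds with values here, no pair of measured compounds here shows this exchange, so the data offer no direct guide to its size.

The expectation therefore starts from compound 1 (0.731) and from the nature of the exchange alone. A modest rise is expected (a number 0.37 log units higher from compound 1 to compound 4 (beyond the scatter)) in this assay, though a result within the scatter would be no surprise. The estimated value for compound 4 is 1.1 (expected range 0.7 to 1.5).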

Compound 4, partition coefficient: 1.32
Estimate against measurement, compound 4: 0.22 log units below, within the range that was stated.
By their numbers in this assay, from the lowest: compounds 1 and 3 (each within the scatter of the next); then compound 4; then compound 2.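

On an aromatic carbon para to a large group, putting formyl in place of hydroxymethyl gives, in this assay, a number 0.59 log units higher from compound 1 to compound 4 (beyond the scatter), so this single exchange moves the number by more than repeat measurements would. The step comes from a small edit: hydroxymethyl and formyl each have 2 heavy atoms (1 carbon, 1 oxygen) and 1 hydrogen-bond acceptor, while hydroxymethyl has 1 hydrogen-bond donor, formyl has 0 hydrogen-bond donors, and formyl has 1 double bond outside aromatic rings. Nothing available here explains why the number moves with this exchange.

Compound 3 carries its hydroxymethyl on a different carbon of the ring, and the compounds shown leave open whether the same exchange there would give a step of similar size. They also leave open how other groups on the same aromatic carbon of the core of compound 1, such as a carboxylic acid, an amine or a longer carbon chain, would compare with hydroxymethyl and formyl.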